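The source may hold more compounds than are shown below. What is called first, only, known or untested is meant among the compounds shown, and "the series" means these compounds.

Measured so far:
Compound 1 `Cc1c(O)c(C)c2c(c1O)C(=O)CC(c1ccc(Cl)cc1)O2`: > 50000 nM
Compound 2 `Cc1c(O)c(C)c2c(c1O)C(=O)CC(c1ccc([N+](=O)[O-])cc1)O2`: > 20000 nM

In a functional assay on HUVEC cells (Homo sapiens) (on this read-out higher numbers stand for an effect only at larger amounts of compound and lower numbers for an effect already at smaller amounts), compound 1 gives > 50000 nM, which is a limit and not a number. Compound 2 gives > 20000 nM, which is also a limit. Compound 3 `Cc1c(O)c(C)c2c(c1O)C(=O)CC(c1ccsc1)O2` carries thiophen-3-yl in place of 4-chlorophenyl on a saturated ring carbon. Among the measured compounds shown here, the only measured step is a step that the two limits leave unreadable from compound 1 to compound 2, and it has no readable size to carry over. With only the limit of compound 1 at > 50000 nM as a starting point, no step beyond the scatter is expected in this assay. The expected step is an at least 1.2-fold lower number from compound 1 to compound 3 (0.09 log units; that floor lies within the scatter). The estimate for compound 3 is 40000 nM, with an expected range from 12000 nM to 100000 nM.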

Compound 3, half-maximal effective concentration: > 50000 nM
Compound 3: no number, only a limit; the forecaster's own chance of this, stated with the estimate: 70%; at least 1.2-fold (0.09 log units) between middle value and limit.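

Among the compounds shown here, no step from compound 1 to compound 3 can be read in this assay, as both values are limits and not numbers: the limit of > 50000 nM in this assay, at which 2 of the 3 values shown sit. The compounds shown leave open at what concentration, if any, compound 1, compound 2 or compound 3 would produce an effect.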